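Pentan-3-yl in place of benzyl(ethyl)amino on a shared core

A few compounds are considered here, and "the series" means these few. Any claim that something is new, unique, unknown or untested is made for them only; others in the source may bear on it.

Measured compounds:
compound 1 `CCN(Cc1ccccc1)c1cc(C)nc(N(CC)c2ccc(C(C)C)cc2Br)n1` — 17 nM
compound 2 `CCN(c1nc(C)cc(C)n1)c1c(Br)cc(N(C)C)cc1OC` — 5 nM
compound 3 `CCCCN(Cc1nn[nH]n1)c1cc(C)nc(N(CC)c2ccc(C(C)C)cc2Br)n1` — limit, > 1000 nM

In an assay on isolated protein for binding affinity to corticotropin-releasing factor receptor 1 (Homo sapiens) (on this read-out higher numbers stand for weaker inhibition and lower numbers for stronger inhibition), compound 1 gives 17 nM, the higher of the two numbers shown. Compound 2 gives 5 nM, and the gap from compound 2 up to compound 1 lies beyond the usual scatter. For compound 3 the read-out is only a limit, > 1000 nM, and not a number. Among the measured compounds shown here, no step between measured compounds that differ in one place is available, so the series offers no measured guide for the change in question. Compound 4 `CCC(CC)c1cc(C)nc(N(CC)c2ccc(C(C)C)cc2Br)n1` differs from compound 1 in one place: pentan-3-yl in place of benzyl(ethyl)amino on an aromatic carbon. In this assay the step of a 1.7-fold lower number from compound 1 to compound 4 (0.23 log units; within the scatter) is expected to be small, within the scatter or slightly toward lower numbers. For compound 4 the expected value is 10 nM, estimated to fall between 3 nM and 40 nM.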

Compound 4, inhibition constant: 2 nM
The estimate for compound 4 lay 5.0-fold (0.70 log units) above the measured number; measured number outside the range, below it.
By their numbers in this assay, from the lowest: compound 4; then compound 2; then compound 1. At a limit, above all of these: compound 3.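

In this assay, pentan-3-yl in place of benzyl(ethyl)amino on an aromatic carbon gives an 8.5-fold lower number from compound 1 to compound 4 (0.93 log units; beyond the scatter) on the shared core. This position therefore needs neither the carbon-only aromatic ring nor the amine nitrogen of benzyl(ethyl)amino for binding, and a group with no ring and no hydrogen-bond acceptor serves in their place. Nothing shown gives a cause for this step.

Open, going by these compounds, is how far the branched chain can shrink or grow at this position, for example to isopropyl or cyclohexyl. Also open, on these data alone, is whether a hydroxyl or a carboxylic acid on pentan-3-yl would be tolerated.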